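Chloro in Place of Hydroxy on Compound 2

The compounds below may be only part of what the source reports. "The series", "measured", "known", "first", "only" and "open" are said of these compounds alone.

Two compounds of this series carry measurements so far. Compound 1 `O=c1ccn(C2CN(S(=O)(=O)c3ccccc3[N+](=O)[O-])c3ccccc3CO2)c(=O)[nH]1` gives 45200 nM in a functional assay on MCF7 cells (Homo sapiens) for antiproliferative activity; on this read-out higher numbers stand for weaker inhibition and lower numbers for stronger inhibition. Compound 2 `O=[N+]([O-])c1ccccc1S(=O)(=O)N1CC(n2cnc3ncnc(O)c32)OCc2ccccc21` gives 19700 nM in this assay. For the measured compounds named here, the single step joining them, a 2.3-fold lower number from compound 1 to compound 2 (0.36 log units; beyond the scatter), exchanges the whole aromatic group on the saturated ring carbon. On these two numbers compound 2 stands lowest, with compound 1 above it by that step.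

Compound 3 `O=[N+]([O-])c1ccccc1S(=O)(=O)N1CC(n2cnc3ncnc(Cl)c32)OCc2ccccc21` differs from compound 2 by chloro in place of hydroxy on an aromatic carbon. Going by the values given here, no measured step bears directly on this change: the one step known, from compound 1 to compound 2, replaced an entire aromatic group rather than a single substituent on it, and it was itself only modest. With nothing pointing in either direction, the step in this assay is expected to be small, possibly within the scatter, and its direction is not predictable from the data at hand. The step from compound 2 to compound 3 is therefore estimated as a 1.3-fold lower number from compound 2 to compound 3 (0.12 log units; within the scatter). Compound 3 is expected to give about 15000 nM in this assay, within a range of 4000 nM to 60000 nM.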

Compound 3, half-maximal inhibitory concentration: 920 nM
Beside the measured number, compound 3's estimate is 16-fold (1.21 log units) above it, and the stated range ends above it.
By their numbers in this assay, from the lowest: compound 3; then compound 2; then compound 1.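

In this assay, exchanging hydroxy for chloro on this one aromatic carbon, opposite the ring nitrogen, gives a 21-fold lower number from compound 2 to compound 3 (1.33 log units; beyond the scatter), a large step, whereas replacing the entire aromatic group gave only a 2.3-fold lower number from compound 1 to compound 2 (0.36 log units; beyond the scatter). This single position therefore weighs far more in the series than the earlier exchange of the whole group suggested, and most of the overall distance, a 49-fold lower number from compound 1 to compound 3 (1.69 log units; beyond the scatter), lies in this one substituent change. No measurement at hand explains why the step is so large.

As far as these compounds go, compound 3 alone stands for the new substituent, so it remains open whether the lower number belongs to chloro itself or to the loss of hydroxy, a question that fluoro, methoxy, an amine or plain hydrogen on the same carbon would help to settle. Also open, from the compounds shown here alone, is whether a step of this size would hold if the nitro group elsewhere in compound 3 gave way to another group, such as an amine.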